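Four Bicyclic Amines and Their Cytotoxicity in Kidney Cells

The compounds below may be only part of what the source reports. "The series", "measured", "known", "first", "only" and "open" are said of these compounds alone.

Compound 1, `C[C@H]1[C@H](NCc2cccs2)C[C@H]2C[C@@H]1C2(C)C`, gives 25000 nM in an ADME assay on MDCK cells (Canis lupus familiaris) for cytotoxicity, read by microscopy, with a stated time of 48 h; on this read-out higher numbers stand for lower toxicity in this test and lower numbers for higher toxicity in this test.
Compound 2, `Cc1csc(CN[C@@H]2C[C@H]3C[C@@H]([C@H]2C)C3(C)C)c1`, gives 12500 nM in this assay.
Compound 3, `Cc1csc(CN[C@@H]2C[C@H]3C[C@@H]([C@H]2C)C3(C)C)n1`, gives only a limit of the assay, > 100000 nM, in this assay.

All three share one saturated bicyclic amine core and differ in the aromatic ring hung on the carbon bound to the amine nitrogen. Between compound 2 and compound 1 the change is hydrogen in place of methyl on an aromatic carbon, and the step is a 2.0-fold higher number from compound 2 to compound 1 (0.30 log units; within the scatter). Between compound 2 and compound 3 the cores differ by 4-methyl-1,3-thiazol-2-yl in place of 4-methylthiophen-2-yl on a saturated chain carbon bound to an amine nitrogen, and the step is an at least 8.0-fold higher number from compound 2 to compound 3 (0.90 log units; beyond the scatter); the related step is an at least 4.0-fold higher number from compound 1 to compound 3 (0.60 log units; beyond the scatter). Compound 3 sits at the limit of > 100000 nM in this assay, at which 1 of the 3 values shown sits, so its true value is not known.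

Compound 4, `C[C@H]1[C@H](NCc2nccs2)C[C@H]2C[C@@H]1C2(C)C`, has not been measured. It differs from compound 3 by hydrogen in place of methyl on an aromatic carbon. This is the same kind of change as from compound 2 to compound 1, though the ring here holds a nitrogen as well and the methyl sits next to that ring nitrogen. Because the earlier step was a 2.0-fold higher number from compound 2 to compound 1 (0.30 log units; within the scatter), the expected step here is a step that the limit leaves unreadable from compound 3 to compound 4. Compound 4 is expected to give 200000 nM, most likely again reported only as a limit.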

Compound 4, minimum cytotoxic concentration: > 100000 nM
Compound 4: a limit, no number; the forecaster's own chance of this, stated with the estimate: 80%; the middle value lies beyond the limit too.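

In this assay compound 4 gives > 100000 nM as a limit of the assay, not a number. The step from compound 3 to compound 4 cannot be read, so this pair does not show whether hydrogen in place of methyl has the same small effect on the 1,3-thiazol-2-yl compounds as on the thiophene compounds, or any effect at all: the limit of > 100000 nM in this assay, at which 2 of the 4 values shown sit. The steps that can be read are an at least 8.0-fold higher number from compound 2 to compound 4 (0.90 log units; beyond the scatter) and an at least 4.0-fold higher number from compound 1 to compound 4 (0.60 log units; beyond the scatter); both lie beyond the scatter, but they describe the swap of the aromatic ring and say nothing separate about the methyl.

The compounds shown leave open how a larger group in place of the methyl, such as an ethyl chain, an amine or a carboxylic acid, would read in this assay. They also leave open how far compound 3 and compound 4 really lie from each other, since neither has a number.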